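Ester for propargyl on the piperazine nitrogen

This account rests on a few compounds, and the source may have more. Where it says the series, first, only, none or still open, it means among the compounds named here.

Compound 1 `CCN(CC)c1ccc2cc(C(=O)c3ccc(N4CCN(C(=O)CN5CCN(S(=O)(=O)c6ccc(OC(F)(F)F)cc6)CC5)CC4)cc3)oc2c1`: 24400 nM
Compound 2 `CCN(CC)c1ccc2cc(C(=O)c3ccc(N4CCN(C(=O)CN5CCN(S(=O)(=O)c6ccc(C(F)(F)F)cc6)CC5)CC4)cc3)oc2c1`: > 40000 nM, a limit of the assay
Compound 3 `C#CCN1CCN(CC(=O)N2CCN(c3ccc(C(=O)c4cc5ccc(N(CC)CC)cc5o4)cc3)CC2)CC1`: 20100 nM

In a functional assay on SGC-7901 cells (Homo sapiens) for cytotoxicity, read by MTT assay, with a stated time of 48 h (on this read-out lower numbers stand for stronger inhibition and higher numbers for weaker inhibition), compound 3 holds the lowest of the two numbers, with compound 1 nearest and within the scatter. Compound 4 `CCOC(=O)CN1CCN(CC(=O)N2CCN(c3ccc(C(=O)c4cc5ccc(N(CC)CC)cc5o4)cc3)CC2)CC1` differs from it by ethoxycarbonyl in place of ethynyl on a saturated chain carbon bound to an amine nitrogen in a ring. Going by the values given here, only one measured step exists, an at least 1.6-fold higher number from compound 1 to compound 2 (0.21 log units; that floor lies within the scatter), and it changes a substituent on the aromatic ring of the sulfonyl group, far from the piperazine carbon altered here, so it bears only loosely on the present change. Compound 4 is therefore expected to show a 1.1-fold higher number from compound 3 to compound 4 (0.04 log units; within the scatter), no step beyond the scatter, and is estimated at 22000 nM with a range from 8000 nM to 40000 nM in this assay.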

Compound 4, half-maximal inhibitory concentration: > 40000 nM
Compound 4: only a limit was reported (the forecaster's own chance of this, stated with the estimate: 25%); middle value at least 1.8-fold (0.25 log units) away from the limit.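

Going by these compounds alone, the change from 4-propargylpiperazin-1-yl to 4-((ethoxycarbonyl)methyl)piperazin-1-yl gives the only step at this position, and in this assay it reads as an at least 1.9-fold higher number from compound 3 to compound 4 (0.29 log units; that floor lies within the scatter). Compound 4 gives > 40000 nM, which is a limit of the assay. This step is therefore a floor only, with its true size unknown, and it shows no change beyond the scatter: the limit of > 40000 nM in this assay, at which 2 of the 4 values shown sit.

As far as these compounds go, what a carboxylic acid or a plain ethyl chain in place of the propargyl would give remains open, as does how far compound 4 lies past its limit.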